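Adding a tert-butoxycarbonyl chain to compound 3

The source may hold more compounds than are shown below. What is called first, only, known or untested is meant among the compounds shown, and "the series" means these compounds.

- Compound 1 `CCN1CCc2c(sc(NC(=O)Nc3ccc(Cl)cc3)c2C(N)=O)C1`: 3120 nM
- Compound 2 `CC(C)(C)OC(=O)CN1CCc2c(sc(NC(=O)Nc3ccc(Cl)cc3)c2C(N)=O)C1`: > 25000 nM, a limit of the assay
- Compound 3 `CC(C)CN1CCc2c(sc(NC(=O)Nc3ccc(Cl)cc3)c2C(N)=O)C1`: 4510 nM

Within the data shown here, in a functional assay (strain AB) with Danio rerio as the target, read by microscopy, with a stated time of 1 h (on this read-out lower numbers stand for an effect already at smaller amounts and higher numbers for an effect only at larger amounts of compound), compound 3 stands level with the only other exact number, with a 1.4-fold higher number from compound 1 to compound 3 (0.16 log units; within the scatter). Compound 4 `CC(C)(C)OC(=O)CCCCCN1CCc2c(sc(NC(=O)Nc3ccc(Cl)cc3)c2C(N)=O)C1` carries 4-(tert-butoxycarbonyl)butyl in place of isopropyl on a saturated chain carbon bound to an amine nitrogen in a ring. The nearest guide is the other compound with tert-butoxycarbonyl, which gave an at least 8.0-fold higher number from compound 1 to compound 2 (0.90 log units; beyond the scatter). Among the measured compounds shown here, no measured compound carries the whole new group, so the guide is only partial. A modest move to a higher number is therefore expected in this assay. The expected change is a 3.1-fold higher number from compound 3 to compound 4 (0.49 log units; beyond the scatter). For compound 4 the estimate is 14000 nM, with an expected range of 4500 nM to 45000 nM.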

Compound 4, half-maximal effective concentration: 620 nM
Compound 4: middle estimate off by 23-fold (1.35 log units), on the high side; the measured number lies below the stated range.
By their numbers in this assay, from the lowest: compound 4; then compounds 1 and 3 (each within the scatter of the next). At a limit, above all of these: compound 2.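

In this assay, a tert-butoxycarbonyl end group does not always raise the number at this position: on the longer 4-(tert-butoxycarbonyl)butyl chain, there is a 7.3-fold lower number from compound 3 to compound 4 (0.86 log units; beyond the scatter) and a 5.0-fold lower number from compound 1 to compound 4 (0.70 log units; beyond the scatter). Against the shorter attachment there is an at least 40-fold lower number from compound 2 to compound 4 (1.60 log units; beyond the scatter), so the same end group gives opposite results depending on the chain holding it. Compound 2 stands at a limit rather than an exact number: the limit of > 25000 nM in this assay, at which 1 of the 4 values shown sits.

As far as these compounds go, whether the gain comes from chain length or from the end group remains open. A plain longer chain or a carboxylic acid at the chain end would separate the two.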